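The source may hold more compounds than are shown below. What is called first, only, known or untested is meant among the compounds shown, and "the series" means these compounds.

Of the compounds shown here, three sharing one core have been measured in a functional assay on K562 cells (Homo sapiens) for inhibition, read by CCK-8 assay, with a stated time of 72 h; a lower number here means a stronger inhibitor, a higher number a weaker inhibitor. Compound 1 `Cc1ccccc1NS(=O)(=O)c1cccc(CCCCCCNC(=O)/C=C/c2cccnc2)c1` gives 0.456 nM, compound 2 `Cc1cccc(NS(=O)(=O)c2cccc(CCCCCCNC(=O)/C=C/c3cccnc3)c2)c1` gives 4.78 nM, and compound 3 `Cc1ccc(C)c(NS(=O)(=O)c2cccc(CCCCCCNC(=O)/C=C/c3cccnc3)c2)c1` gives 0.84 nM. That places compound 3 in the low-number part of this small set. Its two steps read a 1.8-fold higher number from compound 1 to compound 3 (0.27 log units; within the scatter) and a 5.7-fold lower number from compound 2 to compound 3 (0.76 log units; beyond the scatter).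

The unmeasured compound 4 `CC(C)(C)c1ccc(NS(=O)(=O)c2cccc(CCCCCCNC(=O)/C=C/c3cccnc3)c2)cc1` changes only the aromatic group on the sulfonamide: 4-(tert-butyl)phenyl in place of 2,5-dimethylphenyl on a sulfonamide nitrogen. In words, 4-(tert-butyl)phenyl comes in place of 2,5-dimethylphenyl on a sulfonamide nitrogen.

Among the compounds with values here, no measured compound carries a tert-butyl group, so the evidence is indirect. Within the data shown here, two steps bear on the change. The largest is a 10-fold higher number from compound 1 to compound 2 (1.02 log units; beyond the scatter), which shows that this aromatic group can shift the number considerably even when the group count stays the same. The other is a 5.7-fold lower number from compound 2 to compound 3 (0.76 log units; beyond the scatter), a modest step gained by adding a methyl that compound 4 does not have. A rise of modest size is therefore expected, with wide uncertainty, and the expected step in this assay is a 7.1-fold higher number from compound 3 to compound 4 (0.85 log units; beyond the scatter). Compound 4 is estimated at 6 nM, with an expected range from 1.2 nM to 30 nM.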

Compound 4, half-maximal inhibitory concentration: 24.7 nM
For compound 4 the middle estimate is 4.1-fold (0.61 log units) below the measured one, and the stated range covers the measured number.
By their numbers in this assay, from the lowest: compounds 1 and 3 (each within the scatter of the next); then compound 2; then compound 4.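

In this assay the 4-(tert-butyl)phenyl group on a sulfonamide nitrogen puts compound 4 at the high-number end of this set, with a 29-fold higher number from compound 3 to compound 4 (1.47 log units; beyond the scatter) and a 5.2-fold higher number from compound 2 to compound 4 (0.71 log units; beyond the scatter) and also a 54-fold higher number from compound 1 to compound 4 (1.73 log units; beyond the scatter) standing as its three steps. The methyl-bearing compounds had shown only that this aromatic group can move the number; this result shows that a different carbon-only group on the same nitrogen can give a number higher than any of theirs, even though the change adds no hydrogen-bond donors or acceptors and no charge. Nothing measured here accounts for the size of this rise.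

The tert-butyl group differs from the methyl groups in both its identity and its place on the ring, and these four compounds cannot separate those two changes. Also open, from the compounds shown here alone, is how the number would respond to an unsubstituted phenyl, to a 4-methylphenyl, or to a ring carrying an amine or a carboxylic acid on this same sulfonamide nitrogen.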